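From Fluoro to Chloro: Expecting Compound 3

The source may report more compounds than this note shows. Statements on the series, on what has been measured and on what is new or still open speak of the compounds shown alone.

Of the compounds shown here, two have been measured in an assay on a cell-free system (plasma) for inhibition of Dipeptidyl peptidase 4 (Rattus norvegicus), read by fluorescence, with a stated time of 60 min; on this read-out higher numbers stand for weaker inhibition and lower numbers for stronger inhibition. Compound 1, `O=C([C@@H]1C[C@H](N2CCN(c3nc(-c4ccccc4)cs3)CC2)CN1)N1CCSC1`, gives 5.4 nM in this assay. Compound 2, `Cc1cc(N2CCN([C@@H]3CN[C@H](C(=O)N4CCSC4)C3)CC2)n(-c2ccc(F)cc2)n1`, gives 2.3 nM. Compound 2 thus stands with the lowest of the two numbers, and its nearest neighbour, compound 1, lies beyond the usual scatter on the higher side. Among the measured compounds shown here, no pair of measured compounds differs in a single place, so there is no measured step to lean on.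

Compound 3, `Cc1cc(N2CCN([C@@H]3CN[C@H](C(=O)N4CCSC4)C3)CC2)n(-c2ccc(Cl)cc2)n1`, differs from compound 2 by chloro in place of fluoro on an aromatic carbon; cut one bond further out, the change reads 4-fluorophenyl to 4-chlorophenyl. For the measured compounds named here, nothing among the measured compounds speaks to this exchange, so the expectation rests on the change itself. An exchange of one halogen for another on the same aromatic carbon is expected to move the number little; the step of a 1.1-fold higher number from compound 2 to compound 3 (0.04 log units; within the scatter) is expected to stay within the scatter, with no firm direction. Compound 3 is therefore estimated at 2.5 nM, with a range from 1 nM to 6.5 nM.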

Compound 3, half-maximal inhibitory concentration: 2.9 nM
Beside the measured number, compound 3's estimate is 1.2-fold (0.06 log units) below it; measured number inside the range.
By their numbers in this assay, from the lowest: compounds 2, 3 and 1 (each within the scatter of the next, the first and the last beyond it).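

In this assay, chloro in place of fluoro on this aromatic carbon, para to a large group, gives a 1.3-fold higher number from compound 2 to compound 3 (0.10 log units; within the scatter), so the two halogens cannot be told apart at this place. Among the compounds shown here, compounds 1 and 2 differ in more than one place and could give no such reading, which makes this the first single change that can be read: here 4-fluorophenyl and 4-chlorophenyl serve alike in this assay. No other measurement at hand bears on this result or offers a reason for it.

The compounds shown leave open whether this carbon accepts groups other than these two halogens, such as a plain hydrogen, a bromine, a methoxy group, a nitrile, an amine or a carboxylic acid, and whether any of them would move the number beyond the scatter. They also leave open whether the same exchange of fluoro for chloro would read alike at another carbon of the same six-membered aromatic ring.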